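Aryl Ring Changes on a Shared Core in Gastric Cells

The source may report more compounds than this note shows. Statements on the series, on what has been measured and on what is new or still open speak of the compounds shown alone.

Three compounds built on one shared core were tested in a functional assay on MKN-28 cells (Homo sapiens) for antiproliferative activity, read by sulforhodamine B assay, with a stated time of 2 days; on this read-out higher numbers stand for weaker inhibition of growth and lower numbers for stronger inhibition of growth. Compound 1 `O=C(/C=C/c1ccccc1)NCCCCNc1ccnc2cc(Cl)ccc12` gives 16200 nM. Compound 2 `CC(C)c1ccc(/C=C/C(=O)NCCCCNc2ccnc3cc(Cl)ccc23)cc1` gives 22300 nM, the step, which also names the exchanged group, being a 1.4-fold higher number from compound 1 to compound 2 (0.14 log units; within the scatter). Compound 3 `O=C(/C=C/c1ccc(F)cc1)NCCCCNc1ccnc2cc(Cl)ccc12` gives 11800 nM; the steps here, which name the exchanged groups, are a 1.4-fold lower number from compound 1 to compound 3 (0.14 log units; within the scatter) and a 1.9-fold lower number from compound 2 to compound 3 (0.28 log units; within the scatter). Compound 3 holds the lowest of the three numbers, yet its nearest neighbour, compound 1, and its furthest, compound 2, both lie within the scatter of it, so no ranking of the three can be drawn.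

Compound 4 `O=C(/C=C/c1cccc([N+](=O)[O-])c1)NCCCCNc1ccnc2cc(Cl)ccc12` has not yet been measured. It differs from compound 3 by 3-nitrophenyl in place of 4-fluorophenyl on a double-bonded chain carbon bound to a double-bonded chain carbon. All three measured steps bear on this change, since each exchanged one group on the same aromatic ring, and none of them reached beyond the scatter. In this assay the expected step is therefore a 1.2-fold higher number from compound 3 to compound 4 (0.07 log units; within the scatter), which amounts to no movement beyond the scatter. Compound 4 is accordingly estimated at 14000 nM in this assay, with a range from 6000 nM to 35000 nM.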

Compound 4, concentration for 50% growth inhibition: 16200 nM
Compound 4: the middle estimate sits 1.2-fold (0.06 log units) below what was measured; the range from low to high includes it.
By their numbers in this assay, from the lowest: compounds 3, 1, 4 and 2 (each within the scatter of the next).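

In this assay, for the compounds shown here, 3-nitrophenyl is the first aryl group in this set to bring hydrogen-bond acceptors and a double bond outside the aromatic ring, yet it stays within the scatter of all three earlier compounds, with no change at the digits printed from compound 1 to compound 4 (within the scatter), a 1.4-fold higher number from compound 3 to compound 4 (0.14 log units; within the scatter) and a 1.4-fold lower number from compound 2 to compound 4 (0.14 log units; within the scatter). Going by these compounds alone, the aryl group on this double-bonded chain carbon has now been varied four ways, including a nitro group at a ring place that none of the earlier compounds had substituted, and no step among the four compounds goes beyond the scatter, so no ranking can be drawn among them. Nothing available explains this flat result or bears on it in any other way.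

With fluoro, isopropyl and nitro all confined to the scatter, the compounds shown leave open whether a ring amine or carboxylic acid, or a longer chain in place of the one carrying the amide, would move the number beyond it. They also do not separate the group from its ring place, which 4-nitrophenyl and 3-fluorophenyl would do.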